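Aryl alkyne series on the bicyclic amide core

A few compounds are considered here, and "the series" means these few. Any claim that something is new, unique, unknown or untested is made for them only; others in the source may bear on it.

Measured so far:
Compound 1 `Cc1ccc(C#Cc2ccc3c(n2)CCN(C)C3=O)cc1` in an assay on HEK293 cells for displacement of a labelled ligand from metabotropic glutamate receptor 5 (Homo sapiens), with a stated time of 2 h (on this read-out lower numbers stand for stronger inhibition and higher numbers for weaker inhibition), gives 7450 nM.
Compound 2 `Cc1ccc(C#Cc2ccc3c(n2)CCN(C2CCCC2)C3=O)cc1` in this assay gives > 32000 nM.

The second of these is a limit of this assay, not a number; compound 2 is one of the entries that sit at the limit of > 32000 nM in this assay, at which 1 of the 2 values shown sits. On the figures shown, compound 2 thus stands at the weak end of the pair, the step of an at least 4.2-fold higher number from compound 1 to compound 2 (0.63 log units; beyond the scatter) being the only measured step in the set.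

Compound 3 `O=C1c2ccc(C#Cc3cccnc3)nc2CCN1C1CCCC1` differs from compound 2 in a single place: pyridin-3-yl in place of 4-methylphenyl on a triple-bonded carbon. For the measured compounds named here, no measured step touches the aryl end of the alkyne; the one step recorded concerns the amide-type nitrogen of the core and so gives no direct guide here. The change is therefore expected to move this assay little if at all beyond the scatter, with compound 2 already sitting at the limit.

For compound 3 the estimate is 40000 nM, range 12000 nM to 130000 nM. The expected step that the limit leaves unreadable from compound 2 to compound 3 is correspondingly small, and a further limit read-out is anticipated as likely.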

Compound 3, inhibition constant: > 32000 nM
Compound 3 was reported as a limit (the forecaster's own chance of this, stated with the estimate: 60%); the middle value does not contradict the limit.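

In this assay compound 3 gives > 32000 nM as a limit of the assay, not a number. For the compounds shown here, compound 2 is also a limit, so no step between compound 2 and compound 3 can be read. The compounds shown leave open how pyridin-3-yl compares with 4-methylphenyl on a triple-bonded carbon.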